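Swapping vinyl for 3-chloro-4-fluorophenyl on the sulfur chain

The compounds below may be only part of what the source reports. "The series", "measured", "known", "first", "only" and "open" are said of these compounds alone.

Measured in a toxicity assay on GES1 cells (Homo sapiens) for inhibition, read by MTT assay, with a stated time of 72 h; a higher number here means a weaker inhibitor, a lower number a stronger inhibitor:
- compound 1 `Cc1cc(N2CC[C@@H](C)[C@@H](N(C)c3ncnc4[nH]ccc34)C2)n2nc(SCC3CC3)nc2n1`: 27900 nM
- compound 2 `Cc1cc(N2CC[C@@H](C)[C@@H](N(C)c3ncnc4[nH]ccc34)C2)n2nc(SCc3csc4ccc(Cl)cc34)nc2n1`: > 100000 nM
- compound 3 `C=CCSc1nc2nc(C)cc(N3CC[C@@H](C)[C@@H](N(C)c4ncnc5[nH]ccc45)C3)n2n1`: > 100000 nM

Compound 3 stands at > 100000 nM, which is a limit of the assay and not a number. Compound 2 gives > 100000 nM, which is also a limit. Of the position of compound 3 it can be said that it shares (the limit of > 100000 nM in this assay, at which 2 of the 3 values shown sit).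

Compound 4 `Cc1cc(N2CC[C@@H](C)[C@@H](N(C)c3ncnc4[nH]ccc34)C2)n2nc(SCc3ccc(F)c(Cl)c3)nc2n1` has 3-chloro-4-fluorophenyl in place of vinyl on a saturated chain carbon bound to a sulfur.

Three measured steps change this same place. Compound 2 carries 5-chloro-1-benzothiophen-3-yl there, and the change gives an at least 3.5-fold higher number from compound 1 to compound 2 (0.55 log units; beyond the scatter). The vinyl group gives an at least 3.5-fold higher number from compound 1 to compound 3 (0.55 log units; beyond the scatter). The swap closest to the new one, an aromatic group against vinyl, gives a step that the two limits leave unreadable from compound 2 to compound 3, so it cannot fix a size. Both readable steps start from compound 1 and end at the limit, so compound 4 is expected to lie near that limit too, with no step beyond the scatter in this assay. From the compounds shown here alone, the expected step is an at least 1.1-fold lower number from compound 3 to compound 4 (0.04 log units; that floor lies within the scatter), and its direction stays open. For compound 4 the estimated value is 90000 nM, with an expected range from 30000 nM to 270000 nM.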

Compound 4, half-maximal inhibitory concentration: > 100000 nM
Compound 4 gave a limit, no number; the forecaster's own chance of this, stated with the estimate: 55%; at least 1.1-fold (0.04 log units) between middle value and limit.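

In this assay compound 4 gives > 100000 nM, which is a limit of the assay and not a number. With it, three quite different groups on the saturated chain carbon bound to a sulfur, namely vinyl, 5-chloro-1-benzothiophen-3-yl and now 3-chloro-4-fluorophenyl with its single six-membered aromatic ring, all end at the same ceiling, so at this position a plain aromatic ring behaves no differently from the fused ring system or the small vinyl group as far as this assay can tell: the limit of > 100000 nM in this assay, at which 3 of the 4 values shown sit. Among the compounds shown here, compound 1, with cyclopropyl, is the one compound that goes against this and gives a real number, and replacing its cyclopropyl with the new group gives an at least 3.5-fold higher number from compound 1 to compound 4 (0.55 log units; beyond the scatter), while the steps to compound 4 from compound 2 and from compound 3 cannot be read, with limits at both ends.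

From the compounds shown here alone, how compounds 2, 3 and 4 rank among themselves stays open, since none of them has a number. Also open, going by these compounds, is whether an amine, a carboxylic acid or a simple methyl group at this place would give a measurable value, as cyclopropyl does.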